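The source may report more compounds than this note shows. Statements on the series, on what has been measured and on what is new or still open speak of the compounds shown alone.

Measured in an assay on CHO-K1 cells for displacement of a labelled ligand from adenosine receptor A1 (Homo sapiens), read by scintillation counting, with a stated time of 60 min; a higher number here means a weaker inhibitor, a lower number a stronger inhibitor:
compound 1 `Nc1nc(N/N=C/c2ccc(N3CCCC3)cc2)nc2c1ncn2[C@@H]1O[C@H](CO)[C@@H](O)[C@H]1O`: 5.1 nM
compound 2 `Nc1nc(N/N=C/c2cccc(OCc3ccccc3)c2)nc2c1ncn2[C@@H]1O[C@H](CO)[C@@H](O)[C@H]1O`: 13 nM

In this assay compound 1 stands at the lowest of the two numbers, and compound 2 gives a higher value that lies beyond the scatter. Compound 3 `Nc1nc(N/N=C/c2cncs2)nc2c1ncn2[C@@H]1O[C@H](CO)[C@@H](O)[C@H]1O` has not yet been measured. It differs from compound 1 as follows: 1,3-thiazol-5-yl in place of 4-(pyrrolidin-1-yl)phenyl on a carbon with a double bond to nitrogen. Among the measured compounds shown here, no step between the measured compounds covers such a change, so the expectation rests on the change alone. For compound 3 a clear move toward a higher number is expected, estimated as a 7.8-fold higher number from compound 1 to compound 3 (0.89 log units; beyond the scatter). Compound 3 is thus expected to give about 40 nM, within a range from 8 nM to 250 nM.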

Compound 3, inhibition constant: 22 nM
For compound 3 the middle estimate is 1.8-fold (0.26 log units) above the measured one; measured number inside the range.
By their numbers in this assay, from the lowest: compound 1; then compounds 2 and 3 (each within the scatter of the next).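

In this assay, 1,3-thiazol-5-yl in place of 4-(pyrrolidin-1-yl)phenyl gives a 4.3-fold higher number from compound 1 to compound 3 (0.63 log units; beyond the scatter), a modest step and the first measured at this position. Even with this smaller five-membered aromatic ring, compound 3 keeps a value of 22 nM, so the pyrrolidine and the six-membered aromatic ring are not required for binding in this range. Nothing at hand gives a reason for the step.

From the compounds shown here alone, it remains open whether a plain phenyl or a pyridine would lie closer to compound 1 or compound 3. Going by these compounds, the effect of adding an amine or a methyl group to the thiazole also remains open.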